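A few compounds are considered here, and "the series" means these few. Any claim that something is new, unique, unknown or untested is made for them only; others in the source may bear on it.

Of the compounds shown here, three sharing one core have been measured in a functional assay on WM 266-4 cells (Homo sapiens) for inhibition, read by MTT assay, with a stated time of 24 h; on this read-out lower numbers stand for stronger inhibition of growth and higher numbers for weaker inhibition of growth. Compound 1 `O=C(c1ccc2c(c1)OCCO2)N1N=C(c2ccccc2)CC1c1ccccc1F` gives 2500 nM in this assay, compound 2 `O=C(c1ccc2c(c1)OCCO2)N1N=C(c2ccc(Br)cc2)CC1c1ccccc1` gives 1790 nM, and compound 3 `O=C(c1ccc2c(c1)OCCO2)N1N=C(c2ccc(Br)cc2)CC1c1cccc(F)c1` gives 810 nM. Compound 3 therefore stands lowest of the three and shows the strongest inhibition of growth among them. Within the data shown here, the only step between two compounds that differ in one place is a 2.2-fold lower number from compound 2 to compound 3 (0.34 log units; beyond the scatter). Compound 4 `O=C(c1ccc2c(c1)OCCO2)N1N=C(c2ccc(Br)cc2)CC1c1ccccc1F` differs from compound 3 by 2-fluorophenyl in place of 3-fluorophenyl on a saturated ring carbon. Among the measured compounds shown here, no measured step bears directly on moving the fluorine from one position to another on this ring. For the measured compounds named here, the only other compound with a 2-fluorophenyl group is compound 1, which carries phenyl where compounds 2, 3 and 4 carry 4-bromophenyl, and compound 1 gives the highest number in this assay. Going by the values given here, with no direct precedent, a small rise in number is expected, as a 1.9-fold higher number from compound 3 to compound 4 (0.27 log units; within the scatter). Compound 4 is thus expected to give about 1500 nM in this assay, with a range from 600 nM to 4000 nM.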

Compound 4, concentration for 50% growth inhibition: 580 nM
The estimate for compound 4 lay 2.6-fold (0.41 log units) above the measured number; measured number outside the range, below it.
By their numbers in this assay, from the lowest: compounds 4 and 3 (each within the scatter of the next); then compounds 2 and 1 (each within the scatter of the next).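

Moving the fluorine on this ring gives a 1.4-fold lower number from compound 3 to compound 4 (0.15 log units; within the scatter) in this assay and so makes no readable difference: 2-fluorophenyl and 3-fluorophenyl cannot be told apart at this saturated ring carbon. Fluoro in place of hydrogen on this ring still counts at the new position, with a 3.1-fold lower number from compound 2 to compound 4 (0.49 log units; beyond the scatter) as a modest gain that adds a second case to a 2.2-fold lower number from compound 2 to compound 3 (0.34 log units; beyond the scatter) as the earlier one. With 2-fluorophenyl held fixed, bromo in place of hydrogen on the other aromatic ring gives a 4.3-fold lower number from compound 1 to compound 4 (0.63 log units; beyond the scatter) as a modest gain too, the first direct view of that change in this series. On these data alone, whether 4-fluorophenyl, or a chloro or methoxy group on this ring, would fit the same picture remains open. Nothing available here accounts for these differences.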